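This account rests on a few compounds, and the source may have more. Where it says the series, first, only, none or still open, it means among the compounds named here.

Measured in an ADME assay on MT4 cells (Homo sapiens) for cytotoxicity, read by MTT assay, with a stated time of 5 days; on this read-out lower numbers stand for higher toxicity in this test and higher numbers for lower toxicity in this test:
- compound 1 `Cc1cc(C)cc(S(=O)(=O)c2c(C(=O)NC3CNC3)[nH]c3ccc(Cl)cc23)c1`: 37300 nM
- compound 2 `Cc1cc(C)cc(S(=O)(=O)c2c(C(=O)N[C@H]3CCN(Cc4cccnc4)C3)[nH]c3ccc(Cl)cc23)c1`: 22800 nM
- compound 3 `Cc1cc(C)cc(S(=O)(=O)c2c(C(=O)NC3CN(S(C)(=O)=O)C3)[nH]c3ccc(Cl)cc23)c1`: > 252000 nM

Compound 3 is the least toxic of the three, but it is known only as a limit: the limit of > 252000 nM in this assay, at which 1 of the 3 values shown sits.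

Next is compound 4 `Cc1cc(C)cc(S(=O)(=O)c2c(C(=O)NS(=O)(=O)C3CC3)[nH]c3ccc(Cl)cc23)c1`, which has cyclopropylsulfonyl in place of 1-(methylsulfonyl)azetidin-3-yl on an amide-type nitrogen.

For the measured compounds named here, no measured step introduces cyclopropylsulfonyl, so the evidence is indirect. The change between the two amide substituents without a sulfonyl group stays small: a 1.6-fold lower number from compound 1 to compound 2 (0.21 log units; within the scatter). The two steps into compound 3 are much larger: an at least 6.7-fold higher number from compound 1 to compound 3 (0.82 log units; beyond the scatter) and an at least 11-fold higher number from compound 2 to compound 3 (1.04 log units; beyond the scatter). Compound 4 keeps a sulfonyl group and has neither the azetidin-3-yl of compound 1 nor the 1-((pyridin-3-yl)methyl)pyrrolidin-3-yl of compound 2, so it is expected to stay nearer compound 3 than either of them.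

The expected change is an at least 1.2-fold lower number from compound 3 to compound 4 (0.10 log units; that floor lies within the scatter), with no step beyond the scatter anticipated in this assay. A limit reading is also plausible.

For compound 4 the estimated value is 200000 nM, with an expected range of 60000 nM to 300000 nM.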

Compound 4, half-maximal cytotoxic concentration: 147000 nM
Compound 4: middle estimate off by 1.4-fold (0.13 log units), on the high side; low and high end bracket the measured number.
By their numbers in this assay, from the lowest: compounds 2 and 1 (each within the scatter of the next); then compound 4. At a limit, above all of these: compound 3.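

In this assay, the higher numbers that came with a sulfonyl group do not need the azetidine ring: cyclopropylsulfonyl on the amide-type nitrogen, with no ring nitrogen, gives a 3.9-fold higher number from compound 1 to compound 4 (0.60 log units; beyond the scatter) and a 6.4-fold higher number from compound 2 to compound 4 (0.81 log units; beyond the scatter). Between the two sulfonyl-bearing substituents the change reads an at least 1.7-fold lower number from compound 3 to compound 4 (0.23 log units; that floor lies within the scatter), which is only a floor. Compound 3 remains a limit, not a number: the limit of > 252000 nM in this assay, at which 1 of the 4 values shown sits.

Still open, going by these compounds, is how far the true value of compound 3 lies from that of compound 4, and so how much the swap of substituent matters in this assay. Also open, on these data alone, is how acetyl or methylsulfonyl on the amide-type nitrogen would read, and whether a longer alkyl chain in place of the cyclopropyl ring would hold near compound 4 and its 147000 nM reading.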